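A few compounds are considered here, and "the series" means these few. Any claim that something is new, unique, unknown or untested is made for them only; others in the source may bear on it.

Three related compounds have been tested in a functional assay on A549 cells (Homo sapiens) for cytotoxicity, read by WST assay, with a stated time of 24 h; on this read-out higher numbers stand for weaker inhibition and lower numbers for stronger inhibition. Compound 1 `N#C/C(=C\c1c[nH]c2cc(F)ccc12)C(=O)c1c[nH]c2ccccc12` gives 17000 nM in this assay. Compound 2 `COc1ccc2c(C(=O)/C(C#N)=C/c3c[nH]c4cc(F)ccc34)c[nH]c2c1` gives 2400 nM. Compound 3 `COc1ccc2c(C(=O)/C(C#N)=C/c3c[nH]c4ccc(OC)cc34)c[nH]c2c1` gives 3700 nM, and the difference between the cores of compound 3 and compound 2 is not broken down here; their two numbers lie within the scatter of each other.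

One counted change links compound 2 to compound 1: hydrogen in place of methoxy on an aromatic carbon. This change produces a 7.1-fold higher number from compound 2 to compound 1 (0.85 log units; beyond the scatter), so removing the methoxy weakened the compound by a modest but real step.

Compound 4 `COc1ccc2c(C(=O)/C(C#N)=C/c3c[nH]c4ccccc34)c[nH]c2c1` has not yet been measured. For the measured compounds named here, it differs from compound 3 by hydrogen in place of methoxy on an aromatic carbon, a change described in the same words as the one from compound 2 to compound 1, including the words for its place. It is therefore treated as the same kind of change, although it is made at a different spot in compound 3 than in compound 2, so the earlier step is only a guide.

Going by the values given here, for compound 4 the expected step in this assay is a 2.2-fold higher number from compound 3 to compound 4 (0.33 log units; beyond the scatter), resting on compound 2 and compound 1 with a 7.1-fold higher number from compound 2 to compound 1 (0.85 log units; beyond the scatter), tempered because a 7.1-fold higher number from compound 2 to compound 1 (0.85 log units; beyond the scatter) was measured for a change made at a different spot than the one in compound 4, and the two methoxy groups need not weigh alike. The estimate for compound 4 is 8000 nM, expected to fall between 3000 nM and 25000 nM.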

Compound 4, half-maximal inhibitory concentration: 6400 nM
For compound 4 the middle estimate is 1.3-fold (0.10 log units) above the measured one; low and high end bracket the measured number.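

In this assay, taking away the methoxy gives a 1.7-fold higher number from compound 3 to compound 4 (0.24 log units; within the scatter), and this step does not match the one seen earlier for a change described in the same words: the same change on two cores in this assay, a 7.1-fold higher number (0.85 log units; beyond the scatter) from compound 2 to compound 1 and a 1.7-fold higher number (0.24 log units; within the scatter) from compound 3 to compound 4, 4.1-fold (0.61 log units) apart, beyond the scatter of two such steps The change therefore does not carry a fixed size from one core to another in this series, although with only two cases, made at different spots and on different cores, the data cannot show whether the spot, the rest of the core, or both set the size of the step. A separate change on the core of compound 2, hydrogen in place of fluoro, gives a 2.7-fold higher number from compound 2 to compound 4 (0.43 log units; beyond the scatter), but this single case shows nothing about how that change would behave on any other core.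

From the compounds shown here alone, how an amine or a carboxylic acid at these aromatic carbons would move the number remains open, as does the effect of a longer chain such as ethoxy in place of the methoxy. Going by these compounds, it is also open whether the uneven size of the two methoxy steps would recur on cores bearing a chloro group instead of the fluoro.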